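Swapping an oxolanyl for an oxolanyloxy group: what to expect

This account rests on a few compounds, and the source may have more. Where it says the series, first, only, none or still open, it means among the compounds named here.

Compound 1: `O=C(N[C@@H](CC1CCCCC1)C(=O)NCCNc1ccc(OC(F)(F)F)cc1)c1cc2ccccc2o1` — 17 nM
Compound 2: `C[C@@H](CNc1ccc(OC(F)(F)F)cc1)NC(=O)[C@H](CC1CCCCC1)NC(=O)C1CCOC1` — 21 nM
Compound 3: `C[C@@H](CNc1ccc(OC(F)(F)F)cc1)NC(=O)[C@H](CC1CCCCC1)NC(=O)O[C@H]1CCOC1` — 49 nM
Compound 4: `C[C@@H](CNc1ccc(OC(F)(F)F)cc1)NC(=O)[C@H](CC1CCCCC1)NC(=O)O[C@@H]1CCOC1` — not yet measured

In an assay on isolated protein for inhibition of cathepsin S (Homo sapiens) (a lower number here means a stronger inhibitor, a higher number a weaker inhibitor), compound 1 gives 17 nM, compound 2 gives 21 nM and compound 3 gives 49 nM. Among the measured compounds shown here, compound 2 has the second highest of the three numbers; its gap to compound 1 lies within the scatter, while the step of a 2.3-fold higher number from compound 2 to compound 3 (0.37 log units; beyond the scatter) is beyond it and is the only measured step that changes one place at a time.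

Compound 4 differs from compound 2 by the same kind of change: (oxolan-3-yl)oxy in place of oxolan-3-yl on a carbonyl carbon. The entering group carries one defined stereocentre, and compound 4 holds the other arrangement at that centre than compound 3 does. For the measured compounds named here, no measured step tells how the two arrangements compare, so the only guide is the step of a 2.3-fold higher number from compound 2 to compound 3 (0.37 log units; beyond the scatter), a modest weakening.

Compound 4 is therefore expected to give a number close to that of compound 3, which would mean a step of a 2.0-fold higher number from compound 2 to compound 4 (0.30 log units; within the scatter) from compound 2. The estimate for compound 4 in this assay is 42 nM, with a likely range from 18 nM to 100 nM.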

Compound 4, inhibition constant: 42 nM
Beside the measured number, compound 4's estimate shows no gap at the digits printed, within the range that was stated.
By their numbers in this assay, from the lowest: compounds 1, 2, 4 and 3 (each within the scatter of the next, the first and the last beyond it).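

At the ring carbon of the (oxolan-3-yl)oxy group, the arrangement drawn has little bearing on the result in this assay, with a 1.2-fold lower number from compound 3 to compound 4 (0.07 log units; within the scatter). Compound 4 also changes the reading of the swap of oxolan-3-yl for (oxolan-3-yl)oxy on the carbonyl carbon: this arrangement gives a 2.0-fold higher number from compound 2 to compound 4 (0.30 log units; within the scatter), whereas the other gave a 2.3-fold higher number from compound 2 to compound 3 (0.37 log units; beyond the scatter), so the two forms of one change fall on either side of the scatter limit and any cost of the swap looks small rather than firmly established. This comparison tests the stereocentre alone, and that clean reading rests on one fact: the fact that compounds 3 and 4 differ only in the configuration as drawn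

Compound 2 carries its oxolan-3-yl with no defined arrangement, so the compounds shown leave open whether the separate arrangements of that group, without the added oxygen, would give different numbers. They also leave open whether this position tolerates other groups on the carbonyl carbon, such as an (oxan-4-yl)oxy group with its six-membered ring, an open-chain 2-methoxyethoxy group, or an amine that would turn the link into a urea.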